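Hydroxyphenyl dienones: ring pattern and cytotoxicity in PC-12 cells

A few compounds are considered here, and "the series" means these few. Any claim that something is new, unique, unknown or untested is made for them only; others in the source may bear on it.

Three measured compounds share a diene-dione or dienone chain carrying two hydroxyphenyl rings. Compound 1 `O=C(/C=C/c1ccccc1O)CC(=O)/C=C/c1cc(O)ccc1O` gives 38000 nM in an ADME assay on PC-12 cells (Rattus norvegicus) for cytotoxicity, read by WST assay, with a stated time of 24 h; on this read-out higher numbers stand for lower toxicity in this test and lower numbers for higher toxicity in this test. Within the data shown here, compound 2 `O=C(/C=C/c1cccc(O)c1)CC(=O)/C=C/c1cc(O)ccc1O` gives 15000 nM in this assay, and the one counted change between them is 3-hydroxyphenyl in place of 2-hydroxyphenyl on a double-bonded chain carbon bound to a double-bonded chain carbon, with the step of a 2.5-fold lower number from compound 1 to compound 2 (0.40 log units; beyond the scatter). Compound 3 `O=C(/C=C/c1ccccc1O)/C=C/c1cccc(O)c1O` gives 54000 nM in this assay, the highest of the three numbers; its gap to compound 1 lies within the scatter, its gap to compound 2 beyond it. The difference between the cores of compound 1 and compound 3 is not broken down here.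

Compound 4 `O=C(/C=C/c1cccc(O)c1)/C=C/c1cccc(O)c1O` is not yet measured. It differs from compound 3 by 3-hydroxyphenyl in place of 2-hydroxyphenyl on a double-bonded chain carbon bound to a double-bonded chain carbon, the same change as from compound 1 to compound 2, at the same place. Resting on that one measured step, for compound 4 the step of a 2.5-fold lower number from compound 3 to compound 4 (0.39 log units; beyond the scatter) is estimated. In this assay, among the measured compounds shown here, compound 4 is therefore expected at about 22000 nM, between 10000 nM and 48000 nM, with the single precedent leaving this estimate uncertain.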

Compound 4, half-maximal cytotoxic concentration: 46000 nM
The estimate for compound 4 lay 2.1-fold (0.32 log units) below the measured number; measured number inside the range.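

In this assay, among these compounds, 3-hydroxyphenyl in place of 2-hydroxyphenyl gives a 1.2-fold lower number from compound 3 to compound 4 (0.07 log units; within the scatter), so on this core the change leaves no step that can be told from the scatter. Set beside the earlier step, the two cores do not separate: the same change on two cores in this assay, a 2.5-fold lower number (0.40 log units; beyond the scatter) from compound 1 to compound 2 and a 1.2-fold lower number (0.07 log units; within the scatter) from compound 3 to compound 4, 2.2-fold (0.33 log units) apart, within the scatter of two such steps. This shows no measurable difference in how the change carries from one core to the other, but it does not show that the change carries unaltered: the comparison rests on two pairs only, with one step beyond the scatter and the other within it.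

Still open, going by these compounds, is whether the same change gives a comparable step on a third core, and how 4-hydroxyphenyl would stand on a double-bonded chain carbon bound to a double-bonded chain carbon. Also open, on these data alone, is what a methoxyphenyl ring, an amine on the ring or a longer chain would give in this assay.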